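Tert-butoxy for tert-butyl on the hydroxy-bearing side chain

A few compounds are considered here, and "the series" means these few. Any claim that something is new, unique, unknown or untested is made for them only; others in the source may bear on it.

Of the compounds shown here, two have been measured so far in a functional assay on a cell-free system (plasma, Homo sapiens), with a stated time of 3 min; on this read-out higher numbers stand for weaker inhibition and lower numbers for stronger inhibition. Compound 1 `Cc1cccc([C@@H](O)C(=O)N2N=CC[C@H]2C(=O)NCc2cc(Cl)ccc2-n2cnnn2)c1` gives 830 nM. Compound 2 `CC(C)(C)C[C@@H](O)C(=O)N1N=CC[C@H]1C(=O)NCc1cc(Cl)ccc1-n1cnnn1` gives 590 nM. The only single-site step in this assay, a 1.4-fold lower number from compound 1 to compound 2 (0.15 log units; within the scatter), is within the scatter, so compound 2 and compound 1 stand level on the numbers shown. Compound 3 `CC(C)(C)OC[C@@H](O)C(=O)N1N=CC[C@H]1C(=O)NCc1cc(Cl)ccc1-n1cnnn1` differs from compound 2 by tert-butoxy in place of tert-butyl on a saturated chain carbon, two bonds along the chain from a carbonyl carbon and an oxygen on a saturated carbon. Among the compounds with values here, no measured step bears directly on this exchange; the one recorded step, a 1.4-fold lower number from compound 1 to compound 2 (0.15 log units; within the scatter), alters the same side chain and produced no change beyond the scatter. On that basis no step beyond the scatter is expected for compound 3 in this assay, with the step from compound 2 estimated as a 1.0-fold higher number from compound 2 to compound 3 (0.01 log units; within the scatter). Compound 3 is therefore expected to give 600 nM, with a range from 250 nM to 1500 nM.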

Compound 3, half-maximal inhibitory concentration: 750 nM
Estimate against measurement, compound 3: 1.3-fold (0.10 log units) below; the range from low to high includes it.
By their numbers in this assay, from the lowest: compounds 2, 3 and 1 (each within the scatter of the next).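

Within this assay, the exchange of tert-butyl for tert-butoxy gives a 1.3-fold higher number from compound 2 to compound 3 (0.10 log units; within the scatter) at this place, so bringing in an oxygen and its one hydrogen-bond acceptor leaves the number within the scatter. The side chain without a ring also stands level with the one that carries a ring, as a 1.1-fold lower number from compound 1 to compound 3 (0.04 log units; within the scatter) shows for (tert-butoxy)methyl against 3-methylphenyl. Neopentyl, (tert-butoxy)methyl and 3-methylphenyl thus cannot be told apart on this read-out, and none of the three single-site steps now available at this position goes beyond the scatter.

Going by these compounds, it stays open whether an amine, a carboxylic acid or a longer chain at this place would move the number beyond the scatter. Why the oxygen leaves the number where it stands also stays open, as nothing on hand speaks to it.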